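Methoxy Added to the Pyridine Amide of a Pyrazoline

This account rests on a few compounds, and the source may have more. Where it says the series, first, only, none or still open, it means among the compounds named here.

Measured compounds:
compound 1 `COc1ccc(C2=NN(C(=O)c3cccnc3)C(c3cn(C)c4ccc(Br)cc34)C2)cc1OC`: 2380 nM
compound 2 `COc1cc(C2=NN(C(=O)c3cccnc3)C(c3cn(C)c4ccc(Br)cc34)C2)cc(OC)c1OC`: > 10000 nM
compound 3 `COc1ccc2c(c1)c(C1CC(c3ccccc3)=NN1C(=O)c1cccnc1)cn2C`: > 10000 nM

In a functional assay on A549 cells (Homo sapiens) for inhibition, read by MTT assay, with a stated time of 48 h (a lower number here means a stronger inhibitor of growth, a higher number a weaker inhibitor of growth), compound 1 gives 2380 nM. Compound 2 gives only a limit of the assay, > 10000 nM. Compound 3 likewise gives only a limit, > 10000 nM. The change from compound 1 to compound 2 is methoxy in place of hydrogen on an aromatic carbon, and it made an at least 4.2-fold higher number from compound 1 to compound 2 (0.62 log units; beyond the scatter); what is seen here is the limit of > 10000 nM in this assay, at which 2 of the 3 values shown sit. The difference between the cores of compound 1 and compound 3 is not broken down here.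

Compound 4 `COc1ccc2c(c1)c(C1CC(c3ccccc3)=NN1C(=O)c1ccc(OC)nc1)cn2C` is not yet measured. It differs from compound 3 by methoxy in place of hydrogen on an aromatic carbon, the same kind of change as that from compound 1 to compound 2, though the place differs: there the ring was of carbon only, ortho and meta to methoxy groups and meta to a large group; here the ring holds one nitrogen, the methoxy sits next to the ring nitrogen and para to a large group. Since compound 3 already sits at the limit > 10000 nM, the expected step that the limit leaves unreadable from compound 3 to compound 4 is small. Compound 4 is expected to give about 15000 nM, between 5000 nM and 50000 nM.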

Compound 4, concentration for 50% growth inhibition: 1110 nM
Beside the measured number, compound 4's estimate is 14-fold (1.13 log units) above it; measured number below the stated range.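

Changing pyridin-3-yl to 6-methoxypyridin-3-yl gave an at least 9.0-fold lower number from compound 3 to compound 4 (0.95 log units; beyond the scatter) in this assay, and the starting value of that step is only a limit of the assay, so its full size cannot be read. Methoxy in place of hydrogen on an aromatic carbon therefore does not carry one direction of change from one core to the other in this series: the same change on two cores in this assay, an at least 4.2-fold higher number (0.62 log units; beyond the scatter) from compound 1 to compound 2 and an at least 9.0-fold lower number (0.95 log units; beyond the scatter) from compound 3 to compound 4, at least 37-fold (1.57 log units) apart, beyond the scatter of two such steps. What this does not show is whether the core or the place of the methoxy decides the outcome: the two steps differ in both, the first lying on a ring of carbon only and the second on a ring with one nitrogen, and one step on each side makes no rule.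

The compounds shown leave open what the 6-methoxypyridin-3-yl group would do on the core of compound 1, which gives 2380 nM with the plain pyridin-3-yl amide. They also leave open whether an ethoxy group or an amine in the place of this methoxy would keep the growth inhibition seen with compound 4.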